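Extending the benzyl ether of compound 3

The source may hold more compounds than are shown below. What is called first, only, known or untested is meant among the compounds shown, and "the series" means these compounds.

Compound 3 `CC(C)=CCC/C(C)=C/CC1Cc2c(OCc3ccccc3)cc(=O)n(CCCO)c2CC1(C)C` gives 46.5% in a functional assay on PANC-1 cells (Homo sapiens) for inhibition, read by MTT assay, with a stated time of 24 h, tested at 10 uM (on this read-out higher numbers stand for more inhibition at the one concentration tested (going by the name of the read-out) and lower numbers for less inhibition), the second highest of the three numbers measured. Compound 2 `CC(C)=CCC1Cc2c(OC(=O)Nc3ccc(F)cc3F)cc(=O)n(CCCO)c2CC1(C)C` gives 69.7%, and compound 1 `CC(C)=CCC1Cc2c(OCc3ccccc3)cc(=O)n(CCCO)c2CC1(C)C` gives -0.3%. Compound 4 `COc1ccc(OCCCOc2cc(=O)n(CCCO)c3c2CC(C/C=C(\C)CCC=C(C)C)C(C)(C)C3)cc1` differs from compound 3 in one place: 2-(4-methoxyphenoxy)ethyl in place of phenyl on a saturated chain carbon bound to an oxygen on an aromatic ring. Among the compounds with values here, no measured step alters this oxygen-bound group in the same way. The nearest step, a number 70 percentage points higher from compound 1 to compound 2 (beyond the scatter), changes the group on that oxygen to a carbamoyl and is large; a number 46.8 percentage points higher from compound 1 to compound 3 (beyond the scatter) concerns another place. The direction for compound 4 is therefore uncertain, and a step of a number 3.5 percentage points higher from compound 3 to compound 4 (within the scatter) is expected, within the scatter. Compound 4 is estimated at 50%, with a range from 20% to 80%.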

Compound 4, a percentage reported as inhibition, at one concentration (the size of the read-out at that concentration, not a potency): 20%
Compound 4: middle estimate off by 30 percentage points, on the high side; the range from low to high includes it.
By their numbers in this assay, from the lowest: compound 1; then compound 4; then compound 3; then compound 2.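

In this assay the change to 2-(4-methoxyphenoxy)ethyl in place of phenyl on a saturated chain carbon bound to an oxygen on an aromatic ring brings a number 26.5 percentage points lower from compound 3 to compound 4 (beyond the scatter) and shows that this position also responds to a longer ether group that keeps an aromatic ring, not only to the carbamoyl exchange seen earlier. No measured evidence bears on the reason for this drop. The compounds shown leave open how a shorter chain, or an amine in place of the 4-methoxyphenoxy group, would read here.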